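Meta-substituent swaps on a shared oxazolopyridine-free core: chloro entry

A few compounds are considered here, and "the series" means these few. Any claim that something is new, unique, unknown or untested is made for them only; others in the source may bear on it.

Working notes on the aryl substituent at the position described below, read in a functional assay on the whole organism for inhibition, with Rattus norvegicus as the target, at a dose of 30 mg/kg; a higher number here means more inhibition at the dose given (going by the name of the read-out), a lower number less inhibition.

Compound 2 `N#Cc1cccc(-c2nc3ncccc3o2)c1` gives 21% in this assay. Among the measured compounds shown here, its only measured neighbour is compound 1 `Brc1cccc(-c2nc3ncccc3o2)c1`, which gives 23% in this assay; the step of a number 2 percentage points lower from compound 1 to compound 2 (within the scatter) is within the scatter, so the two values cannot be told apart and compound 2 cannot be called weaker than compound 1 on these numbers.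

Compound 3 `Clc1cccc(-c2nc3ncccc3o2)c1` is not yet measured. Its difference from compound 2 is chloro in place of cyano on an aromatic carbon.

For the measured compounds named here, only one measured step bears on this change: from compound 1 to compound 2, a halogen gave way to cyano, and the read-out moved by a number 2 percentage points lower from compound 1 to compound 2 (within the scatter), within the scatter. The step to compound 3 goes the other way, from cyano back to a halogen, so the expectation from that single pairing is a step of about a number 2 percentage points higher from compound 2 to compound 3 (within the scatter), that is, no change beyond the scatter. Going by the values given here, with only two measured compounds, the range must stay wide. The estimate for compound 3 in this assay is 23%, expected to fall between 10% and 36%.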

Compound 3, a percentage reported as inhibition, in the whole organism at one dose (the size of the read-out at that dose, not a potency): 32%
For compound 3 the middle estimate is 9 percentage points below the measured one; the measured number falls inside the stated range.
By their numbers in this assay, from the lowest: compounds 2, 1 and 3 (each within the scatter of the next, the first and the last beyond it).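

In this assay, among the compounds shown here, chloro in place of cyano on an aromatic carbon gives a number 11 percentage points higher from compound 2 to compound 3 (beyond the scatter) and is the first step in this small set to clear the scatter, so the group at this place can move the read-out at this dose. Chloro in place of bromo gives a number 9 percentage points higher from compound 1 to compound 3 (within the scatter) and does not separate the two halogens, and bromo stays inseparable from cyano as well, so only the two ends of the order, compound 2 and compound 3, can be told apart. A clean split of halogens against the nitrile is therefore not supported, with compound 1 going against it, and nothing on hand speaks to the reason for the step.

The compounds shown leave open whether a fluoro, a methoxy, an amine or a carboxylic acid at this place would extend the range or fall within it. With the read-out at a single dose, they also leave open whether the gap between the chloro and cyano compounds would hold at other doses.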